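The compounds below may be only part of what the source reports. "The series", "measured", "known", "first", "only" and "open" are said of these compounds alone.

Measured compounds in an assay on FRT cells for positive allosteric modulation of Cystic fibrosis transmembrane conductance regulator variant N1303K (Homo sapiens), in the presence of a further agent that is not named here; on this read-out lower numbers stand for an effect already at smaller amounts and higher numbers for an effect only at larger amounts of compound:
- compound 1, `COc1ccc2[nH]c3c(c2c1)CCNC31CCN(Cc2cc(Cl)ccc2[N+](=O)[O-])CC1`: 7100 nM
- compound 2, `COc1ccc2[nH]c3c(c2c1)CCNC31CCN(Cc2cc(F)cc(Cl)c2)CC1`: 2500 nM
- compound 3, `COc1ccc2[nH]c3c(c2c1)CCNC31CCN(Cc2c(F)ccc(Cl)c2F)CC1`: 1500 nM

Compound 3 gives the lowest of the three numbers in this assay. The step of a 1.7-fold lower number from compound 2 to compound 3 (0.22 log units; within the scatter) lies within the scatter, so these two cannot be told apart; the step of a 4.7-fold lower number from compound 1 to compound 3 (0.68 log units; beyond the scatter) is a real difference.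

Compound 4, `COc1ccc2[nH]c3c(c2c1)CCNC31CCN(Cc2ccccn2)CC1`, differs from compound 3 in one place: pyridin-2-yl in place of 3-chloro-2,6-difluorophenyl on a saturated chain carbon bound to an amine nitrogen in a ring.

Going by the values given here, no measured step swaps a halogen-bearing ring for a nitrogen-containing ring, so the three measured steps bear only indirectly on this change. They show that the ring attached to the chain carbon matters: a 2.8-fold lower number from compound 1 to compound 2 (0.45 log units; beyond the scatter) and a 4.7-fold lower number from compound 1 to compound 3 (0.68 log units; beyond the scatter) are modest but real, while a 1.7-fold lower number from compound 2 to compound 3 (0.22 log units; within the scatter) is not. Since both lower numbers came with rings that carry halogens, and compound 4 carries none, a higher number than for compound 3 is expected, probably of modest size, as a 3.3-fold higher number from compound 3 to compound 4 (0.52 log units; beyond the scatter).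

Compound 4 is therefore estimated to give about 5000 nM in this assay, most likely between 1500 nM and 20000 nM.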

Compound 4, half-maximal effective concentration: 11500 nM
The estimate for compound 4 lay 2.3-fold (0.36 log units) below the measured number; measured number inside the range.
By their numbers in this assay, from the lowest: compounds 3 and 2 (each within the scatter of the next); then compounds 1 and 4 (each within the scatter of the next).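

Swapping the ring on this chain carbon to pyridin-2-yl gives a real loss in this assay, seen both as a 7.7-fold higher number from compound 3 to compound 4 (0.88 log units; beyond the scatter) and as a 4.6-fold higher number from compound 2 to compound 4 (0.66 log units; beyond the scatter) against the two compounds whose rings carry only halogens. The change is not a loss against every ring, however: a 1.6-fold higher number from compound 1 to compound 4 (0.21 log units; within the scatter) means that compound 1 and compound 4 cannot be told apart. A chlorine on the ring is therefore not enough for a lower number, since compound 1 carries one and still stays level with the halogen-free compound 4, so it goes against any simple halogen pattern.

From the compounds shown here alone, it remains open whether a plain phenyl ring or a pyridin-3-yl ring would fall with compound 3 or with compound 4. No supporting data explain why these rings differ.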